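A few compounds are considered here, and "the series" means these few. Any claim that something is new, unique, unknown or untested is made for them only; others in the source may bear on it.

In a functional assay on Huh-7 cells (Homo sapiens) for inhibition, read by CCK-8 assay, with a stated time of 72 h (on this read-out higher numbers stand for weaker inhibition and lower numbers for stronger inhibition), two compounds have numbers so far:

compound 1 `CC(C)(C)c1ccc(NS(=O)(=O)c2cccc(CCCCCCNC(=O)/C=C/c3cccnc3)c2)cc1`: 163 nM
compound 2 `O=C(/C=C/c1cccnc1)NCCCCCCc1cccc(S(=O)(=O)Nc2ccc(F)c(Cl)c2)c1`: 39.4 nM

Compound 2 holds the lower of these two numbers. Compound 3 `O=C(/C=C/c1cccnc1)NCCCCCCc1cccc(S(=O)(=O)Nc2ccc(C(F)(F)F)cc2)c1` carries 4-(trifluoromethyl)phenyl in place of 3-chloro-4-fluorophenyl on a sulfonamide nitrogen. Within the data shown here, one measured step bears on this place, a 4.1-fold lower number from compound 1 to compound 2 (0.62 log units; beyond the scatter), which is modest and beyond the scatter. Among the measured compounds shown here, with only that step as a guide, a modest move towards a higher number is expected in this assay, though it may stay within the scatter. The estimated step is a 1.9-fold higher number from compound 2 to compound 3 (0.28 log units; within the scatter). For compound 3 the expected value is 75 nM, with an expected range of 28 nM to 200 nM.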

Compound 3, half-maximal inhibitory concentration: 164 nM
Compound 3: middle estimate off by 2.2-fold (0.34 log units), on the low side; the range from low to high includes it.
By their numbers in this assay, from the lowest: compound 2; then compounds 1 and 3 (each within the scatter of the next).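

In this assay, the move to 4-(trifluoromethyl)phenyl gives a 4.2-fold higher number from compound 2 to compound 3 (0.62 log units; beyond the scatter), so the lower number of compound 2 does not carry over to this group on the sulfonamide nitrogen. Trifluoromethyl in place of tert-butyl on an aromatic carbon gives a 1.0-fold higher number from compound 1 to compound 3 (0.00 log units; within the scatter), which leaves these two groups indistinguishable here, and so far 3-chloro-4-fluorophenyl alone stands apart. No measurement shown here accounts for this.

As far as these compounds go, whether the chlorine, the fluorine or both set compound 2 apart remains open. So does the outcome with an amine or a carboxylic acid on this aromatic ring.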